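Formamidine pyrazoles: formyl loss and para chloro swap

The compounds below may be only part of what the source reports. "The series", "measured", "known", "first", "only" and "open" are said of these compounds alone.

Working notes on a small set of pyrazole formamidines tested for growth inhibition in a functional assay on NCI-H226 cells (Homo sapiens) for inhibition, read by MTT assay, with a stated time of 72 h; a higher number here means a weaker inhibitor of growth, a lower number a stronger inhibitor of growth.

Compound 1 `Cc1ccc(-c2nn(-c3cccc(Cl)c3)c(/N=C/N(C)C)c2C=O)cc1` gives 8900 nM in this assay. Compound 2 `CN(C)/C=N/c1c(C=O)c(-c2ccc(Cl)cc2)nn1-c1cccc(Cl)c1` gives 9200 nM in this assay. The two are related by a single change, (chloro in place of methyl on an aromatic carbon), and the step of a 1.0-fold higher number from compound 1 to compound 2 (0.01 log units; within the scatter) shows that this swap leaves the number essentially where it was.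

Compound 3 `Cc1ccc(-c2cc(/N=C/N(C)C)n(-c3cccc(Cl)c3)n2)cc1` gives 80900 nM in this assay. Its core differs from that of compound 1 by hydrogen in place of formyl on an aromatic carbon, and the step of a 9.1-fold higher number from compound 1 to compound 3 (0.96 log units; beyond the scatter) is the one clear movement in the set, putting compound 3 at the weak end, beyond the scatter from both compound 1 and compound 2.

Compound 4 `CN(C)/C=N/c1cc(-c2ccc(Cl)cc2)nn1-c1cccc(Cl)c1` has not yet been measured. Within the data shown here, it relates to compound 3 by chloro in place of methyl on an aromatic carbon, which is the same change as the one that takes compound 1 to compound 2, at a place described in identical terms. Because the earlier instance a 1.0-fold higher number from compound 1 to compound 2 (0.01 log units; within the scatter) sat within the scatter, the expected step for compound 4 is a 1.0-fold higher number from compound 3 to compound 4 (0.01 log units; within the scatter), also within the scatter, resting on that one precedent and on the weak standing of compound 3 given by 80900 nM. Compound 4 is therefore expected to give about 83000 nM in this assay, most likely between 40000 nM and 170000 nM.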

Compound 4, concentration for 50% growth inhibition: 75600 nM
Beside the measured number, compound 4's estimate is 1.1-fold (0.04 log units) above it; measured number inside the range.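

In this assay, the change from 4-methylphenyl to 4-chlorophenyl gives a 1.1-fold lower number from compound 3 to compound 4 (0.03 log units; within the scatter) on the core without the formyl group, so the swap leaves the number in place on both cores, and the two instances agree: the same change on two cores in this assay, a 1.0-fold higher number (0.01 log units; within the scatter) from compound 1 to compound 2 and a 1.1-fold lower number (0.03 log units; within the scatter) from compound 3 to compound 4, 1.1-fold (0.04 log units) apart, within the scatter of two such steps.

Removing the formyl group also carries across, since the chloro pair shows an 8.2-fold higher number from compound 2 to compound 4 (0.91 log units; beyond the scatter) and this step matches the one seen in the methyl pair: the same change on two cores in this assay, a 9.1-fold higher number (0.96 log units; beyond the scatter) from compound 1 to compound 3 and an 8.2-fold higher number (0.91 log units; beyond the scatter) from compound 2 to compound 4, 1.1-fold (0.04 log units) apart, within the scatter of two such steps.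

Together the four compounds show that, in this one assay, the two changes read independently of each other, but this rests on a single pair of instances for each change and does not show that either step would hold on a core outside this set, or that the place on the ring is indifferent to groups other than methyl and chloro.

Among these compounds, it remains open whether a methoxy group, a trifluoromethyl group or an amine in place of the chloro would move the number, given that only two closely matched groups are compared there. On these data alone, it is equally open whether a carboxylic acid, a nitrile or a hydroxymethyl group in place of the formyl would hold the number near that of compound 1 or let it fall back towards that of compound 3.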